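Swapping a methyl for hydrogen on the aryl ring

The source may hold more compounds than are shown below. What is called first, only, known or untested is meant among the compounds shown, and "the series" means these compounds.

Compound 1 `COc1cc2c(Oc3ccc(NC(=O)c4nn(-c5ccccc5C(F)(F)F)ccc4=O)cc3)ccnc2cc1OCC(=O)NO` | > 20000 nM
Compound 2 `COc1cc2c(Oc3ccc(NC(=O)c4nn(-c5ccccc5C)cc(C)c4=O)cc3F)ccnc2cc1OCCCC(=O)NO` | 2090 nM

Both entries come from a functional assay on A549 cells (Homo sapiens) for inhibition, read by MTT assay, with a stated time of 72 h (a lower number here means a stronger inhibitor, a higher number a weaker inhibitor), and the entry for compound 1 is a limit, not a number. For the measured compounds named here, of the two entries, compound 2 at 2090 nM gives the only true number.

Compound 3 `COc1cc2c(Oc3ccc(NC(=O)c4nn(-c5ccccc5)cc(C)c4=O)cc3F)ccnc2cc1OCCCC(=O)NO` has not yet been measured in this assay and differs from compound 2 in one place hydrogen in place of methyl on an aromatic carbon with hydrogen in place of methyl on an aromatic carbon, a change from 2-methylphenyl to phenyl. The carbon concerned belongs to a six-membered aromatic ring of carbon only and stands ortho to a large group.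

Going by the values given here, no step between measured compounds shows what such a change does. The expected change a 1.0-fold higher number from compound 2 to compound 3 (0.00 log units; within the scatter) is therefore none beyond the scatter, in neither direction. Among the compounds with values here, this expectation rests on compound 2 at 2090 nM as the only number available. For compound 3 the estimate is 2100 nM with 800 nM to 6000 nM as its expected range.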

Compound 3, half-maximal inhibitory concentration: 1900 nM
For compound 3 the middle estimate is 1.1-fold (0.04 log units) above the measured one; measured number inside the range.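

In this assay, for the compounds shown here, the pair gives the first readable step for this aromatic carbon, ortho to a large group: a 1.1-fold lower number from compound 2 to compound 3 (0.04 log units; within the scatter). Within this single pair, then, the methyl of the 2-methylphenyl group can be replaced by hydrogen, leaving phenyl, and the two numbers cannot be told apart, so this methyl shows no measurable contribution to the read-out on this shared core. Nothing measured here offers a cause for this outcome.

Compound 1, which carries a trifluoromethyl on its aryl ring, gives > 20000 nM, a limit and not a number, and it differs from compound 2 in more than one place, so it cannot show what that group does at this position. As far as these compounds go, whether a chlorine, an amine or a carboxylic acid on this same aromatic carbon would also stay within the scatter remains open, as does whether the step from methyl to hydrogen would read the same on a different core or in another assay.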